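Trimming the Benzoyl from Compound 2

A few compounds are considered here, and "the series" means these few. Any claim that something is new, unique, unknown or untested is made for them only; others in the source may bear on it.

Among the measured compounds shown here, in an in vitro assay on Sf9 cells for binding affinity to RAC-alpha serine/threonine-protein kinase (Homo sapiens), tested at 30 uM (on this read-out lower numbers stand for weaker stabilisation of the target and higher numbers for stronger stabilisation of the target against heat), compound 2 `Nc1ncccc1-c1nc2cccnc2n1-c1ccc(NC(=O)c2ccccc2)cc1` gives 7.3 degrees C, the higher of the two numbers measured so far. Compound 1 `Nc1ncccc1-c1nc2cc(C3CCCC3)cnc2n1-c1ccc(CNC(=O)c2ccccc2)cc1` gives 6 degrees C in this assay, a number lower by more than the usual scatter. Compound 3 `Nc1ccc(-n2c(-c3cccnc3N)nc3cccnc32)cc1` differs from compound 2 by hydrogen in place of benzoyl on a nitrogen on an aromatic ring, benzamido to amino. For the measured compounds named here, no measured pair shows this change, so its size rests on expectation alone. The step is expected to be downward, a number 4.3 degrees C lower from compound 2 to compound 3 (beyond the scatter), since compound 2 reaches 7.3 degrees C with the benzoyl present. Compound 3 is therefore estimated at 3 degrees C, within 0.5 degrees C to 6 degrees C.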

Compound 3, shift of the target's melting temperature: 4.1 degrees C
For compound 3 the middle estimate is 1.1 degrees C below the measured one; low and high end bracket the measured number.
By their numbers in this assay, from the lowest: compound 3; then compound 1; then compound 2.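

In this assay, the change from benzamido to amino on a nitrogen on an aromatic ring gives a number 3.2 degrees C lower from compound 2 to compound 3 (beyond the scatter) and so puts a first measured size on losing the benzoyl at this position. Without the benzoyl, compound 3 still gives 4.1 degrees C of stabilisation, so the benzoyl is not required for a shift in melting temperature. No evidence is available to explain the size of this step.

The compounds shown leave open how much of the step belongs to the carbonyl and how much to the aromatic ring of the benzoyl. An acetyl on this nitrogen would separate the two, while a phenylacetyl would show how a longer chain behaves here.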